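The source may report more compounds than this note shows. Statements on the series, on what has been measured and on what is new or still open speak of the compounds shown alone.

Of the compounds shown here, three have been measured in a physicochemical assay for acid dissociation. Compound 1 `COc1cc(C(=O)N[C@@H]2CCC[C@@H]3CCN(C)C[C@H]32)cc(OC)c1OC` gives 8.75, compound 2 `COc1ccccc1C(=O)N[C@@H]1CCC[C@@H]2CCN(C)C[C@H]21` gives 8.81, and compound 3 `CN1CC[C@H]2CCC[C@@H](NC(=O)c3ccccc3)[C@@H]2C1` gives 8.99. The difference between the cores of compound 1 and compound 2 is not broken down here. Between compound 2 and compound 3 the change is hydrogen in place of methoxy on an aromatic carbon, and in this assay the step was a number 0.18 log units higher from compound 2 to compound 3 (within the scatter). Compound 4 `COc1ccc(C(=O)N[C@@H]2CCC[C@@H]3CCN(C)C[C@H]32)cc1OC` is not yet measured; it arises from compound 1 by hydrogen in place of methoxy on an aromatic carbon. This is the same kind of change, but its surroundings differ: in compound 1 the aromatic carbon is ortho to a methoxy group, meta to a large group and meta to a methoxy group, whereas in compound 2 it is ortho to a large group. Because the step of a number 0.18 log units higher from compound 2 to compound 3 (within the scatter) lay within the scatter, only a small step is expected here. For compound 4 the expected step is a number 0.10 log units higher from compound 1 to compound 4 (within the scatter). Compound 4 is thus estimated at 8.85, with a range from 8.55 to 9.15.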

Compound 4, acid dissociation constant: 8.89
Compound 4: middle estimate off by 0.04 log units, on the low side; the range from low to high includes it.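

In this assay, hydrogen in place of methoxy gives a number 0.14 log units higher from compound 1 to compound 4 (within the scatter), and on the other core the same change gave a number 0.18 log units higher from compound 2 to compound 3 (within the scatter). Within the data shown here, both steps lie within the scatter, so on these two cores and in these two different surroundings the change has no step that can be told from repeat noise, but this does not show that the two steps are equal or that the surroundings make no difference. Nothing shown here bears on what lies behind these numbers.

The compounds shown carry only methoxy or hydrogen at the changed places, so it remains open how an amine or a carboxylic acid there would read. From the compounds shown here alone, whether any single change on this aromatic ring can produce a step beyond the scatter also remains open.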